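Stereochemical Variants and Cytotoxicity in Breast Cancer Cells

This account rests on a few compounds, and the source may have more. Where it says the series, first, only, none or still open, it means among the compounds named here.

Compound 1 `CC(C)[C@H]1CC[C@H](C)C[C@@H]1O[C@@H]1O[C@H](CO[C@@H]2O[C@H](COC(=O)c3ccc(Br)cc3)[C@@H](OC(=O)c3ccc(Br)cc3)[C@H](O)[C@H]2O)[C@@H](O)[C@H](O)[C@H]1O`: 16000 nM
Compound 2 `CC(C)[C@@H]1CC[C@@H](C)C[C@H]1O[C@@H]1O[C@H](CO[C@@H]2O[C@H](COC(=O)c3ccc(Br)cc3)[C@@H](OC(=O)c3ccc(Br)cc3)[C@H](O)[C@H]2O)[C@@H](O)[C@H](O)[C@H]1O`: 12900 nM

Of the compounds shown here, two have been measured in a functional assay on MCF7 cells (Homo sapiens) for cytotoxicity, read by MTT assay, with a stated time of 72 h; a higher number here means a weaker inhibitor, a lower number a stronger inhibitor. Compound 1 gives 16000 nM and compound 2 gives 12900 nM. On these numbers compound 2 sits alongside compound 1: the step of a 1.2-fold lower number from compound 1 to compound 2 (0.09 log units; within the scatter) lies within the scatter, so the two cannot be told apart. The only thing separating them is the fact that compounds 1 and 2 differ only in the configuration as drawn.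

Compound 3 `CC(C)[C@H]1CC[C@H](C)C[C@@H]1O[C@H]1O[C@H](CO[C@@H]2O[C@H](COC(=O)c3ccc(Br)cc3)[C@@H](OC(=O)c3ccc(Br)cc3)[C@H](O)[C@H]2O)[C@@H](O)[C@H](O)[C@H]1O` has not yet been measured. Compared with compound 2, (the two compounds have the same atoms and bonds and differ only in configuration as drawn: 4 of 13 stereo elements differ; a stereocentre at a saturated ring carbon is drawn S in compound 2 and R in compound 3; a stereocentre at a saturated ring carbon is drawn R in compound 2 and S in compound 3; a stereocentre at a saturated ring carbon is drawn R in compound 2 and S in compound 3; a stereocentre at a saturated ring carbon is drawn R in compound 2 and S in compound 3). Among the measured compounds shown here, this is again a change of configuration alone, with the same atoms and bonds throughout, and the single measured step of that kind, a 1.2-fold lower number from compound 1 to compound 2 (0.09 log units; within the scatter), produced no shift beyond the scatter. For the measured compounds named here, with only one such step to go on, the expectation for this assay is no change beyond the scatter in either direction. Compound 3 is therefore expected to give about 14000 nM, with a range from 6000 nM to 35000 nM. The step this estimate implies is a 1.1-fold higher number from compound 2 to compound 3 (0.04 log units; within the scatter), which is expected to stay within the scatter.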

Compound 3, half-maximal inhibitory concentration: 6100 nM
For compound 3 the middle estimate is 2.3-fold (0.36 log units) above the measured one, and the stated range covers the measured number.
By their numbers in this assay, from the lowest: compound 3; then compounds 2 and 1 (each within the scatter of the next).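

In this assay, configuration alone now moves the number beyond the scatter: a 2.6-fold lower number from compound 1 to compound 3 (0.42 log units; beyond the scatter), and the two compounds differ at only one stereocentre at a saturated ring carbon, drawn R in compound 1 and S in compound 3. Changing three other stereocentres gave a 1.2-fold lower number from compound 1 to compound 2 (0.09 log units; within the scatter), while changing those three together with this one gave a 2.1-fold lower number from compound 2 to compound 3 (0.33 log units; beyond the scatter), so among these compounds only the steps that include this centre lie beyond the scatter, and both are modest. The structures tie the shift to nothing more specific than this: the fact that compounds 1 and 3 differ only in the configuration as drawn.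

The compounds shown leave open what the same R-to-S change would do if the other three stereocentres were held as drawn in compound 2, since none of them has that combination. They also leave open whether the shift would persist if the two 4-bromobenzoate esters gave way to plain benzoate esters or to amides, as every compound here carries the same ester groups.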